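This account rests on a few compounds, and the source may have more. Where it says the series, first, only, none or still open, it means among the compounds named here.

Series notes. Compound 1 `Cc1nn(C)c2c1C(c1cccc(Cl)c1)=NCCN2CCCN(C)C` and compound 2 `Cc1nn(C)c2c1C(c1ccccc1)=NCCN2CCCN(C)C` sit on one core, compound 3 `Cc1nn(C)c2c1C(c1ccc(Cl)c(Cl)c1)=NCCN2` and compound 4 `Cc1nn(C)c2c1C(c1ccc(Cl)cc1)=NCCN2` on another; the difference between the two cores is not broken down here. In a functional assay on the whole organism for positive allosteric modulation, with Rattus norvegicus as the target (on this read-out lower numbers stand for an effect already at smaller amounts and higher numbers for an effect only at larger amounts of compound), compound 1 gives > 10 mg/kg, which is a limit of the assay and not a number. Compound 2 gives > 10 mg/kg in this assay, again a limit. For the measured compounds named here, compound 3 gives 2.5 mg/kg in this assay, the only number among the three. The change from compound 1 to compound 2 is hydrogen in place of chloro on an aromatic carbon; its step that the two limits leave unreadable from compound 1 to compound 2 cannot be read because of the limit of > 10 mg/kg in this assay, at which 2 of the 3 values shown sit. The change from compound 3 to compound 4 is hydrogen in place of chloro on an aromatic carbon, the same kind of change, though here the place is ortho to a chloro group as well as meta to a large group, whereas from compound 1 to compound 2 it is meta to a large group only. Going by the values given here, with the earlier step unreadable, the expected step of a 2.0-fold higher number from compound 3 to compound 4 (0.30 log units; within the scatter) is kept modest, resting on compound 3 at 2.5 mg/kg as the sole number. Compound 4 is estimated at 5 mg/kg, expected between 2.5 mg/kg and 10 mg/kg.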

Compound 4, minimum effective dose: 2.5 mg/kg
Compound 4: the middle estimate sits 2.0-fold (0.30 log units) above what was measured; measured number inside the range.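

In this assay, hydrogen in place of chloro on an aromatic carbon, at the place ortho to a chloro group and meta to a large group, reads as no change at the digits printed from compound 3 to compound 4 (within the scatter). The same kind of change on the core of compound 1 cannot be read, so the two cores cannot be compared for it: the limit of > 10 mg/kg in this assay, at which 2 of the 4 values shown sit. What remains is a single readable pair on one core, which shows that this chloro can be exchanged for hydrogen there without a step beyond the scatter, but does not show that the change carries from one core to the other, and the place also differs between the two pairs.

Still open, as far as these compounds go, is whether methoxy, fluoro or trifluoromethyl at the same place on the core of compound 3 would sit with compound 3 and compound 4 in this assay. Also open, from the compounds shown here alone, is what hydrogen in place of the remaining chloro of compound 4 would give.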